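A few compounds are considered here, and "the series" means these few. Any claim that something is new, unique, unknown or untested is made for them only; others in the source may bear on it.

Values so far in an ADME assay on Vero cells (Chlorocebus sabaeus) for cytotoxicity, read by MTT assay; on this read-out lower numbers stand for higher toxicity in this test and higher numbers for lower toxicity in this test:
- compound 1 `Cn1nc(C(F)(F)F)cc1C(=O)Nc1ccc(S(=O)(=O)N2CCCCCC2)cc1` gives > 300000 nM as a limit
- compound 2 `Cn1nc(C(F)(F)F)cc1C(=O)Nc1ccc(S(=O)(=O)n2ccc3ccccc32)cc1` gives 13000 nM as a measured number
- compound 3 `Cn1nc(C(F)(F)F)cc1C(=O)Nc1ccc(S(=O)(=O)N2CCC(C(F)(F)F)CC2)cc1` gives 159000 nM as a measured number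

Compound 3 holds the higher of the two true numbers, with compound 2 well under it. Next comes compound 4 `Cn1nc(C(F)(F)F)cc1C(=O)Nc1ccc(S(=O)(=O)OC2CCCCC2)cc1`, in which cyclohexyloxy takes the place of 4-(trifluoromethyl)piperidin-1-yl on a sulfonyl sulfur cyclohexyloxy in place of 4-(trifluoromethyl)piperidin-1-yl on a sulfonyl sulfur while the rest stays the same.

Three measured steps change this same group. Putting 1H-indol-1-yl in place of azepan-1-yl gave an at least 23-fold lower number from compound 1 to compound 2 (1.36 log units; beyond the scatter), and putting 4-(trifluoromethyl)piperidin-1-yl in place of 1H-indol-1-yl gave a 12-fold higher number from compound 2 to compound 3 (1.09 log units; beyond the scatter) as a large recovery. Putting 4-(trifluoromethyl)piperidin-1-yl in place of azepan-1-yl gave only an at least 1.8-fold lower number from compound 1 to compound 3 (0.27 log units; that floor lies within the scatter) as a change.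

Cyclohexyloxy has a non-aromatic ring, as the groups of compounds 1 and 3 do, so compound 4 is expected to stay nearer compound 3 at 159000 nM than compound 2 at 13000 nM in this comparison. Going by the values given here, no measured compound carries cyclohexyloxy, so the guide is thin. The expected change is a 2.7-fold lower number from compound 3 to compound 4 (0.42 log units; beyond the scatter) as a modest move to a lower number. For compound 4 the estimate is 60000 nM, with an expected range from 15000 nM to 240000 nM here.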

Compound 4, half-maximal cytotoxic concentration: > 300000 nM
Compound 4: no number, only a limit (the forecaster's own chance of this, stated with the estimate: 10%); middle value at least 5.0-fold (0.69 log units) away from the limit.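

In this assay compound 4 gives > 300000 nM, a limit and not a number, so its step from compound 1 cannot be read: the limit of > 300000 nM in this assay, at which 2 of the 4 values shown sit.

Putting cyclohexyloxy on the sulfonyl sulfur gives an at least 1.8-fold higher number from compound 3 to compound 4 (0.27 log units; that floor lies within the scatter), a floor too small to separate the two, and an at least 23-fold higher number from compound 2 to compound 4 (1.36 log units; beyond the scatter). This shows that a ring joined through oxygen can keep the number as high as rings joined through nitrogen do, and among the four compounds only compound 2, with its aromatic 1H-indol-1-yl, goes against this high level.

Still open, going by these compounds, is whether the low number of compound 2 belongs to aromatic rings in general or to 1H-indol-1-yl alone, which a phenoxy group on the sulfonyl sulfur could test. An open chain such as butoxy would also show whether a ring is needed there at all.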